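The source may hold more compounds than are shown below. What is called first, only, known or untested is meant among the compounds shown, and "the series" means these compounds.

Measured so far in an ADME assay on Huh-7 cells (Homo sapiens) for cytotoxicity; on this read-out lower numbers stand for higher toxicity in this test and higher numbers for lower toxicity in this test:
- compound 1 `O=c1cc(CNCc2cccc(Cl)c2)oc2ccc(O)c(O)c12` — > 100000 nM
- compound 2 `O=c1cc(CNCc2cccc(Br)c2)oc2ccc(O)c(O)c12` — > 100000 nM
- compound 3 `O=c1cc(CNCc2cccc([N+](=O)[O-])c2)oc2ccc(O)c(O)c12` — > 100000 nM

All three share one core and differ only in the group on the pendant ring. For compound 1 the value shown is a limit of the assay, not a number. For compound 2 the value shown is likewise a limit. For compound 3, too, the value shown is only a limit, so compound 3 stands at the edge of what this assay can report, with no exact figure. Because all three values sit at the limit of > 100000 nM in this assay, at which 3 of the 3 values shown sit, none of the steps between them can be read: a step that the two limits leave unreadable from compound 1 to compound 2, a step that the two limits leave unreadable from compound 1 to compound 3 and a step that the two limits leave unreadable from compound 2 to compound 3.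

Compound 4 `Cc1cccc(CNCc2cc(=O)c3c(O)c(O)ccc3o2)c1` is not yet measured. Compared with compound 3 it carries methyl in place of nitro on an aromatic carbon. Only the three unreadable steps bear on this change; within the reportable range they show no separation between the chloro, bromo and nitro compounds, so no step beyond the scatter is expected. Compound 4 is expected to come in near 150000 nM, with a range from 60000 nM to 400000 nM, most probably again as a limit. The expected step in this assay is a step that the limit leaves unreadable from compound 3 to compound 4.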

Compound 4, half-maximal cytotoxic concentration: > 100000 nM
Compound 4 gave a limit, no number; the forecaster's own chance of this, stated with the estimate: 80%; the middle value lies beyond the limit too.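

In this assay, among these compounds, compound 4 also gives only a limit, so no step among compound 1, compound 2, compound 3 and compound 4 can be read: the limit of > 100000 nM in this assay, at which 4 of the 4 values shown sit.

The compounds shown leave open how far apart these four truly lie, and whether any group on the pendant ring gives a measurable number.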